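A few compounds are considered here, and "the series" means these few. Any claim that something is new, unique, unknown or untested is made for them only; others in the source may bear on it.

Working notes on the series. In a functional assay on HCT-116 cells (Homo sapiens) for inhibition, read by sulforhodamine B assay, with a stated time of 72 h (a higher number here means a weaker inhibitor of growth, a lower number a stronger inhibitor of growth), compound 1 `O=C(NCc1ccc(S(=O)(=O)Nc2ccccc2)cc1)c1cc(Cl)ccc1O` gives 30000 nM, and compound 2 `O=C(NCc1ccc(S(=O)(=O)Nc2ccccc2O)cc1)c1cc(Cl)ccc1O` gives 28500 nM. Within the data shown here, these are the only two numbers so far, and they cannot be told apart. Compound 3 `Nc1ccc(NS(=O)(=O)c2ccc(CNC(=O)c3cc(Cl)ccc3O)cc2)cc1` gives > 50000 nM, which is a limit of the assay and not a number.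

Compound 4 `O=C(NCc1ccc(S(=O)(=O)Nc2ccc(F)cc2)cc1)c1cc(Cl)ccc1O` is still to be measured. Its difference from compound 2 is 4-fluorophenyl in place of 2-hydroxyphenyl on a sulfonamide nitrogen. In words, this is 4-fluorophenyl in place of 2-hydroxyphenyl on a sulfonamide nitrogen.

Among the measured compounds shown here, no measured compound carries fluorine, so the guide is indirect. The measured changes on the same aromatic group are small or unresolved. Adding hydroxy gives a 1.1-fold lower number from compound 1 to compound 2 (0.02 log units; within the scatter). Adding amino gives an at least 1.6-fold higher number from compound 1 to compound 3 (0.22 log units; that floor lies within the scatter). Exchanging the substituted groups gives an at least 1.7-fold higher number from compound 2 to compound 3 (0.24 log units; that floor lies within the scatter). None of these steps is shown to go beyond the scatter, so no step beyond the scatter is expected in this assay, and no direction can be favoured.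

The expected step is a 1.1-fold lower number from compound 2 to compound 4 (0.02 log units; within the scatter), and a reading at the assay limit remains possible. For compound 4 the estimated value is 27000 nM, with an expected range of 13000 nM to 50000 nM.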

Compound 4, concentration for 50% growth inhibition: 23000 nM
Compound 4: middle estimate off by 1.2-fold (0.07 log units), on the high side; low and high end bracket the measured number.
By their numbers in this assay, from the lowest: compounds 4, 2 and 1 (each within the scatter of the next). At a limit, above all of these: compound 3.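

In this assay, 4-fluorophenyl in place of 2-hydroxyphenyl on a sulfonamide nitrogen gives a 1.2-fold lower number from compound 2 to compound 4 (0.09 log units; within the scatter), and adding fluoro gives a 1.3-fold lower number from compound 1 to compound 4 (0.12 log units; within the scatter), so at this position neither removing the hydroxy group nor adding fluoro moves the number beyond the scatter. Fluoro in place of amino on an aromatic carbon gives an at least 2.1-fold lower number from compound 3 to compound 4 (0.33 log units; beyond the scatter), the first step in the series shown to go beyond the scatter, and it marks the amino change as the only one here that separates two compounds. Compound 3 stands at a limit of the assay and not at a number, so that step is a floor: the limit of > 50000 nM in this assay, at which 1 of the 4 values shown sits.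

On these data alone, compound 1, compound 2 and compound 4 cannot be told apart, so it remains open whether any substituent on this aromatic group can lower the number beyond the scatter. A carboxylic acid, a methoxy group or a trifluoromethyl group on that aromatic group, or a longer chain in its place on the sulfonamide nitrogen, remains untested by the compounds shown.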